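A few compounds are considered here, and "the series" means these few. Any claim that something is new, unique, unknown or untested is made for them only; others in the source may bear on it.

Measured compounds in a functional assay on LAC cells (Homo sapiens) for cytotoxicity, read by MTT assay, with a stated time of 72 h; a higher number here means that more compound is needed for the effect, a lower number that less compound is needed:

compound 1, `CCS[C@@H]1[C@H](SCC)[C@@H](Cn2cc(-c3ccc(F)cc3)nn2)O[C@H]1n1ccc(=O)[nH]c1=O`, gives 72400 nM.
compound 2, `CCS[C@@H]1[C@H](SCC)[C@@H](Cn2cc(-c3ccc(OC)cc3)nn2)O[C@H]1n1ccc(=O)[nH]c1=O`, gives 24300 nM.
compound 3, `CCS[C@@H]1[C@H](SCC)[C@@H](Cn2cc(-c3ccc(F)cc3)nn2)O[C@H]1n1cc(C)c(=O)[nH]c1=O`, is reported only as a limit of the assay, >= 100000 nM.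

The pair of compounds 1 and 2 carries the change (methoxy in place of fluoro on an aromatic carbon). This change gives a 3.0-fold lower number from compound 1 to compound 2 (0.47 log units; beyond the scatter).

Compound 3 differs from compound 1 in its core by methyl in place of hydrogen on an aromatic carbon. The step is an at least 1.3-fold higher number from compound 1 to compound 3 (0.14 log units; that floor lies within the scatter); the value of compound 3 is a limit, so the size of this step is not fixed, and the same holds for any step that starts from compound 3. The limit at which compound 3 sits is the limit of >= 100000 nM in this assay, at which 1 of the 3 values shown sits.

Compound 4, `CCS[C@@H]1[C@H](SCC)[C@@H](Cn2cc(-c3ccc(OC)cc3)nn2)O[C@H]1n1cc(C)c(=O)[nH]c1=O`, is not yet measured in this assay. It differs from compound 3 by methoxy in place of fluoro on an aromatic carbon, and the surroundings of the place are the same as for the pair of compounds 1 and 2, so this is the same change made on the other core. The expected step of an at least 2.2-fold lower number from compound 3 to compound 4 (0.34 log units; beyond the scatter) rests on the earlier step of a 3.0-fold lower number from compound 1 to compound 2 (0.47 log units; beyond the scatter) being applied from a starting point that is only a limit, so a number for compound 4 is expected to be somewhat more likely than for compound 3 but by no means certain.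

Compound 4 is expected to give about 45000 nM, within 20000 nM to 150000 nM, in this assay.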

Compound 4, half-maximal effective concentration: 25900 nM
Compound 4: middle estimate off by 1.7-fold (0.24 log units), on the high side; the range from low to high includes it.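

In this assay, the change from 4-fluorophenyl to 4-methoxyphenyl gives a lower number on both cores, and the new step is an at least 3.8-fold lower number from compound 3 to compound 4 (0.58 log units; beyond the scatter), so the direction carries over in these two pairs: the same change on two cores in this assay, a 3.0-fold lower number (0.47 log units; beyond the scatter) from compound 1 to compound 2 and an at least 3.8-fold lower number (0.58 log units; beyond the scatter) from compound 3 to compound 4; the limit leaves it open whether they differ.
The value of compound 3, >= 100000 nM, is a limit of the assay, so these data do not show whether the change is equally large on the two cores, only that it points the same way in both pairs.
The methyl step with methoxy in place lies within the scatter, at a 1.1-fold higher number from compound 2 to compound 4 (0.03 log units; within the scatter), and its comparison with the fluoro pair stays unresolved: the same change on two cores in this assay, an at least 1.3-fold higher number (0.14 log units; that floor lies within the scatter) from compound 1 to compound 3 and a 1.1-fold higher number (0.03 log units; within the scatter) from compound 2 to compound 4; the limit leaves it open whether they differ.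

The compounds shown hold only fluoro and methoxy at this place on the aromatic ring, so it remains open how an amine, a hydroxyl or a carboxylic acid there would read on either core. As far as these compounds go, it also remains open whether a longer chain in place of the methyl on the core would leave the number within the scatter, and whether the shared direction would hold on a third core.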